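The source may hold more compounds than are shown below. What is called first, only, known or untested is meant among the compounds shown, and "the series" means these compounds.

Three compounds have been measured in a functional assay on MCF7 cells (Homo sapiens) for inhibition; a lower number here means a stronger inhibitor, a higher number a weaker inhibitor:

Compound 1 `CC/C(=C(/c1ccc(/C=C/C(=O)O)cc1)c1cc2ccccc2[nH]1)c1ccccc1Cl` gives 42 nM.
Compound 2 `CC/C(=C(/c1ccc(/C=C/C(=O)O)cc1)c1cc2ccccc2[nH]1)c1ccccc1C(F)(F)F` gives 8 nM.
Compound 3 `CC/C(=C(/c1ccc(/C=C/C(=O)O)cc1)c1cc2ccccc2[nH]1)c1ccc(C#N)cc1` gives 278 nM.

Compound 3 stands as the highest number of the three, that is the weakest inhibitor. Its nearest neighbour is compound 1, and the gap there is a 6.6-fold higher number from compound 1 to compound 3 (0.82 log units; beyond the scatter). The gap to compound 2 is wider: a 35-fold higher number from compound 2 to compound 3 (1.54 log units; beyond the scatter). Between compounds 1 and 2 the difference is a 5.3-fold lower number from compound 1 to compound 2 (0.72 log units; beyond the scatter).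

Compound 4 `CC/C(=C(/c1ccc(/C=C/C(=O)O)cc1)c1cc2ccccc2[nH]1)c1ccc(C(F)(F)F)cc1Cl` has not yet been measured. It differs from compound 3 in one place: 2-chloro-4-(trifluoromethyl)phenyl in place of 4-cyanophenyl on a double-bonded chain carbon bound to a double-bonded chain carbon and a saturated chain carbon.

Going by the values given here, two measured steps bear on this change. Replacing the 2-chlorophenyl of compound 1 by the 4-cyanophenyl of compound 3 raised the number by a modest amount, and the same ring swap from compound 2 raised it by a large amount. Compound 4 brings back the chloro seen in compound 1 and adds a trifluoromethyl elsewhere on the ring. The number for compound 4 is therefore expected to fall back toward that of compound 1, a step of a 5.6-fold lower number from compound 3 to compound 4 (0.75 log units; beyond the scatter) in this assay. The estimate for compound 4 is 50 nM, with a range from 15 nM to 200 nM.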

Compound 4, half-maximal inhibitory concentration: 27 nM
For compound 4 the middle estimate is 1.9-fold (0.27 log units) above the measured one; the measured number falls inside the stated range.
By their numbers in this assay, from the lowest: compound 2; then compounds 4 and 1 (each within the scatter of the next); then compound 3.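

Exchanging 4-cyanophenyl for 2-chloro-4-(trifluoromethyl)phenyl on this double-bonded chain carbon gives a 10-fold lower number from compound 3 to compound 4 (1.01 log units; beyond the scatter) in this assay, so a ring carrying two substituents is accepted here and can give a much lower number than 4-cyanophenyl does. Adding a trifluoromethyl to the 2-chlorophenyl ring of compound 1 gives a 1.6-fold lower number from compound 1 to compound 4 (0.19 log units; within the scatter), so compounds 1 and 4 cannot be told apart in this assay, and this added trifluoromethyl shows no measurable effect when the chloro is already present. Placing the new ring against the 2-(trifluoromethyl)phenyl ring of compound 2 gives a 3.4-fold higher number from compound 2 to compound 4 (0.53 log units; beyond the scatter), which leaves compound 2 with the lowest number of the four and shows that having more substituents on the ring does not by itself lower the number.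

Still open, going by these compounds, is how the large step away from compound 3 divides between losing the nitrile and gaining the chloro and trifluoromethyl, and whether a ring carrying an amine or a methoxy group at this position would sit nearer compound 2 or compound 3. No measurement offered here explains why these rings differ.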